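A few compounds are considered here, and "the series" means these few. Any claim that something is new, unique, unknown or untested is made for them only; others in the source may bear on it.

In a physicochemical assay, read by spectrophotometry, with a stated time of 30 min (on this read-out lower numbers stand for stronger inhibition and higher numbers for weaker inhibition), the measured compounds read as follows:

Compound 1 `O=C(CC(c1ccc(Cl)cc1)c1c[nH]c2ccccc12)c1c(O)c2ccccc2oc1=O` gives 46.4 ug/mL
Compound 2 `O=C(CC(c1ccc(F)cc1)c1c[nH]c2ccccc12)c1c(O)c2ccccc2oc1=O` gives 47.4 ug/mL
Compound 3 `O=C(CC(c1ccc(O)cc1)c1c[nH]c2ccccc12)c1c(O)c2ccccc2oc1=O` gives 58.9 ug/mL

Compound 3 is not separated from the other two. The steps (a 1.3-fold higher number from compound 1 to compound 3 (0.10 log units; within the scatter) and a 1.2-fold higher number from compound 2 to compound 3 (0.09 log units; within the scatter)) are small, as is the third (a 1.0-fold higher number from compound 1 to compound 2 (0.01 log units; within the scatter)). Compound 4 `N#Cc1ccc(C(CC(=O)c2c(O)c3ccccc3oc2=O)c2c[nH]c3ccccc23)cc1` carries cyano in place of hydroxy on an aromatic carbon at the place that varies among the other three. All three measured steps exchange the group at that place and none leaves the scatter, but none introduces cyano, so they bear on this change only indirectly. In this assay no step beyond the scatter is therefore expected, and no direction can be given. The expected step (a 1.2-fold lower number from compound 3 to compound 4 (0.07 log units; within the scatter)) stays within the scatter. For compound 4 the estimated value is 50 ug/mL with an expected range from 30 ug/mL to 80 ug/mL in this read-out.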

Compound 4, half-maximal inhibitory concentration: 13.7 ug/mL
Compound 4: middle estimate off by 3.6-fold (0.56 log units), on the high side; the whole stated range lies above it.
By their numbers in this assay, from the lowest: compound 4; then compounds 1, 2 and 3 (each within the scatter of the next).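

In this assay the exchange of groups at this place, flat among chloro, fluoro and hydroxy, now leaves the scatter: cyano moves the number down from hydroxy (a 4.3-fold lower number from compound 3 to compound 4 (0.63 log units; beyond the scatter)), from fluoro (a 3.5-fold lower number from compound 2 to compound 4 (0.54 log units; beyond the scatter)) and from chloro (a 3.4-fold lower number from compound 1 to compound 4 (0.53 log units; beyond the scatter)). The position therefore does respond to what it carries, and compound 4 stands apart from the other three, towards stronger inhibition. Nothing available explains this shift. As far as these compounds go, whether an amine, a carboxylic acid or a longer chain at this place would move the number the same way remains open.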